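The source may hold more compounds than are shown below. What is called first, only, known or untested is meant among the compounds shown, and "the series" means these compounds.

Working notes on the series. Compound 1 `COc1ccc(-c2cc(-c3ccc(S(=O)(=O)N(C)C)cc3)cnc2N)cn1` and compound 2 `COc1ccc(-c2cc(-c3ccc(C(F)(F)F)cc3)cnc2N)cn1` share one core and differ only in the group on the outer aromatic ring. In a physicochemical assay for lipophilicity, at pH 7.4 (a lower number here means a more polar compound, a higher number a more lipophilic compound), compound 1 gives 2.8 and compound 2 gives 4.2. For the measured compounds named here, the step of a number 1.40 log units higher from compound 1 to compound 2 (beyond the scatter) is the one measured change in the set. Going by the values given here, on the numbers so far compound 2 stands highest of the two, with compound 1 the nearest and lower by that same margin.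

Compound 3 `CNC(=O)c1ccc(-c2cnc(N)c(-c3ccc(OC)nc3)c2)cc1` is not yet measured. It differs from compound 2 by methylcarbamoyl in place of trifluoromethyl on an aromatic carbon. Among the compounds with values here, only the step from compound 1 to compound 2 bears on this exchange, and it was large; replacing trifluoromethyl with a group that carries a hydrogen-bond donor and acceptor is expected to move this assay down by a comparable amount, a number 1.60 log units lower from compound 2 to compound 3 (beyond the scatter). Compound 3 is therefore estimated at 2.6, between 2.1 and 3.1.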

Compound 3, distribution coefficient: 1.8
Beside the measured number, compound 3's estimate is 0.80 log units above it; measured number below the stated range.
By their numbers in this assay, from the lowest: compound 3; then compound 1; then compound 2.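

At this aromatic carbon, para to a large group, this assay has a wider range than the earlier pair showed: the exchange of trifluoromethyl for methylcarbamoyl gives a number 2.40 log units lower from compound 2 to compound 3 (beyond the scatter) and exceeds the step seen with dimethylsulfamoyl, even though the entering and leaving groups match in heavy-atom count. Dimethylsulfamoyl also no longer marks the low end of the series, since the exchange for methylcarbamoyl gives a number 1.00 log units lower from compound 1 to compound 3 (beyond the scatter) and this smaller step still stands clear of the scatter. Nothing on hand accounts for the size of either step.

The compounds shown leave open where a nitrile, a carboxylic acid or an amine would fall at this place in this assay. They also leave open whether the amide hydrogen or the methyl group of methylcarbamoyl matters, which the unsubstituted carboxamide and the dimethylcarbamoyl group would separate.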